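Ureas on a shared core: a chlorine moved on the phenyl

A few compounds are considered here, and "the series" means these few. Any claim that something is new, unique, unknown or untested is made for them only; others in the source may bear on it.

Measured compounds:
compound 1, `CC1(C)CC(NC(=O)Nc2ccc(Cl)cc2)c2cc(Br)ccc2O1`, 25000 nM
compound 2, `CC1(C)CC(NC(=O)Nc2cccc(Cl)c2)c2cc(F)ccc2O1`, 39000 nM

In a functional assay on U-373MG ATCC cells (Homo sapiens) for inhibition, read by MTT assay, with a stated time of 72 h (a higher number here means a weaker inhibitor, a lower number a stronger inhibitor), compound 2 gives 39000 nM, the highest of the two numbers. Its nearest neighbour is compound 1, which gives 25000 nM in this assay; the gap between the two lies within the scatter, so nothing can be said about which of them inhibits more strongly. Both numbers sit in a weak region of the scale.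

Compound 3, `CC1(C)CC(NC(=O)Nc2ccc(Cl)cc2)c2cc(F)ccc2O1`, has not yet been measured in this assay. It differs from compound 2 in one place: 4-chlorophenyl in place of 3-chlorophenyl on an amide-type nitrogen. The two compounds have the same atoms, joined differently.

Among the measured compounds shown here, no step between two measured compounds is available to set a scale for this change. Compound 1 carries the 4-chlorophenyl group that enters here, and its number does not stand apart from that of compound 2 beyond the scatter. Compound 3 is therefore expected to show a small step from compound 2 toward a lower number, a 1.3-fold lower number from compound 2 to compound 3 (0.11 log units; within the scatter), most likely not beyond the scatter. The estimate for compound 3 in this assay is 30000 nM, expected to fall between 12000 nM and 75000 nM.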

Compound 3, half-maximal inhibitory concentration: 24000 nM
Compound 3: middle estimate off by 1.3-fold (0.10 log units), on the high side, within the range that was stated.
By their numbers in this assay, from the lowest: compounds 3, 1 and 2 (each within the scatter of the next).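

Among the compounds shown here, the new result gives the first direct reading of where the chlorine sits on the phenyl in this assay: 4-chlorophenyl in place of 3-chlorophenyl on the amide-type nitrogen amounts to a 1.6-fold lower number from compound 2 to compound 3 (0.21 log units; within the scatter) and so does not separate the two placements. For the compounds shown here, it also gives the first one-place comparison at the other site, where fluoro in place of bromo on an aromatic carbon amounts to a 1.0-fold lower number from compound 1 to compound 3 (0.02 log units; within the scatter) and so does not separate these two halogens either. Neither change takes a compound out of the weak region of the scale, and no further data bear on this result.

Going by these compounds, what remains open is whether a group of another kind on the phenyl, such as a trifluoromethyl, a methoxy or a carboxylic acid in place of the chlorine, would give a number that stands beyond the scatter from those of these three ureas. On these data alone, it is equally open whether a hydrogen, a methyl or a nitrile in place of the halogen on the aromatic carbon of the shared core would do so.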